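A few compounds are considered here, and "the series" means these few. Any claim that something is new, unique, unknown or untested is made for them only; others in the source may bear on it.

Working notes on the series. Compound 1 `NC1=NC2(CCSCC2)N(OCCCOc2ccc(Cl)c(Cl)c2)C(N)=N1` gives 88.4% in an assay on isolated protein for inhibition of Dihydrofolate reductase (Homo sapiens), read by spectrophotometry, using NADPH, with stated times of 5 s and 6 min, tested at 5 uM; a higher number here means a stronger effect of the compound at the concentration tested, a lower number a weaker effect. Compound 3 `NC1=NC2(CCOCC2)N(OCCCOc2cccc(Br)c2)C(N)=N1` gives 86.7% in this assay. Compound 2 `COc1ccc(OCCCON2C(N)=NC(N)=NC23CCOCC3)cc1` gives > 90% in this assay, which is a limit of the assay and not a number (the limit of > 90% in this assay, at which 1 of the 3 values shown sits). Among the compounds with values here, the one measured step that bears on the change, a number at least 3.3 percentage points lower from compound 2 to compound 3 (that floor lies within the scatter), touches the same aryl oxygen on the saturated carbon. Compound 4 `NC1=NC2(CCOCC2)N(OCCCOc2ccc(Br)cc2)C(N)=N1` differs from compound 2 by bromo in place of methoxy on an aromatic carbon. As the move from compound 2 to compound 3 stayed within the scatter, no step beyond the scatter is expected here either, and compound 4 is estimated at 88% in this assay, between 80% and 93%, a step of a number at least 2 percentage points lower from compound 2 to compound 4 (that floor lies within the scatter) that is expected to sit within the scatter.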

Compound 4, a percentage reported as inhibition, at one concentration (the size of the read-out at that concentration, not a potency): > 90%
Compound 4 gave a limit, no number; the forecaster's own chance of this, stated with the estimate: 30%; at least 2 percentage points between middle value and limit.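

With 4-bromophenyl in place of 4-methoxyphenyl, compound 4 reads as a limit of the assay and not a number, so the step from compound 2 cannot be read. 4-Bromophenyl in place of 3-bromophenyl gives a number at least 3.3 percentage points higher from compound 3 to compound 4 (that floor lies within the scatter), a floor that leaves the true size of the step open. A second compound now rests on that limit, so this position can no longer be ranked in this assay: the limit of > 90% in this assay, at which 2 of the 4 values shown sit.

Going by these compounds, whether an amine or a carboxylic acid in place of bromo would give a readable number stays open. On these data alone, the order of compounds at the limit also stays open.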